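One Substituent Swap on a Shared Antiproliferative Core

A few compounds are considered here, and "the series" means these few. Any claim that something is new, unique, unknown or untested is made for them only; others in the source may bear on it.

Compound 1 `CCONC(=O)c1sc(N2N=C(c3ccc(C)cc3)CC2c2cc3cc(OC)ccc3nc2Cl)nc1C`: 38 nM
Compound 2 `COc1ccc2nc(Cl)c(C3CC(c4ccc(C)cc4)=NN3c3nc(-c4ccc(Cl)cc4)cs3)cc2c1`: 38 nM

Of the compounds shown here, two have been measured. In a functional assay on DLD-1 cells (Homo sapiens) for antiproliferative activity (a lower number here means a stronger inhibitor, a higher number a weaker inhibitor), compound 1 gives 38 nM. Compound 2, which carries a different group on the ring amine nitrogen of the shared core, gives 38 nM. For the measured compounds named here, the only step so far, no change at the digits printed from compound 1 to compound 2 (within the scatter), shows that exchanging that whole group left the result where it was. Compound 1 therefore stands level with compound 2, and neither can be called the stronger inhibitor.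

Compound 3 `COc1ccc2nc(Cl)c(C3CC(c4ccc(C)cc4)=NN3c3nc(C)c(/N=N/c4ccccc4)s3)cc2c1` has not yet been measured. Compared with compound 1, the change is a group of 8 heavy atoms (6 carbon, 2 nitrogen; one six-membered aromatic ring of carbon only) in place of a group of 6 heavy atoms (3 carbon, 1 nitrogen, 2 oxygen; no ring), on an aromatic carbon. Going by the values given here, the one measured step bears only loosely on this: the step from compound 1 to compound 2 replaced the entire group on that nitrogen without any effect beyond the scatter, which suggests that this part of the molecule tolerates large changes. A smaller swap within the same group is therefore expected to change little, so the step of a 1.1-fold higher number from compound 1 to compound 3 (0.02 log units; within the scatter) is expected to stay within the scatter. Compound 3 is estimated at 40 nM, in the range 15 nM to 110 nM.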

Compound 3, half-maximal inhibitory concentration: 38 nM
Beside the measured number, compound 3's estimate is 1.1-fold (0.02 log units) above it; measured number inside the range.
By their numbers in this assay, from the lowest: compounds 1, 2 and 3 (each within the scatter of the next).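

The step of no change at the digits printed from compound 1 to compound 3 (within the scatter) in this assay is narrower than the earlier exchange of the whole group on the ring amine nitrogen: it changes only the group on an aromatic carbon of the five-membered aromatic ring with 1 nitrogen and 1 sulfur, next to the ring sulfur. Here ethoxycarbamoyl, with no ring and 1 hydrogen-bond donor, gives way to a group with one six-membered aromatic ring of carbon only and 0 hydrogen-bond donors, so for this pair neither that donor nor the absence of a ring at this place is needed to keep the number where it was. Nothing available explains why the value stays put through this exchange.

From the compounds shown here alone, whether a carboxylic acid, a primary amine or a bare hydrogen at this place would also leave the number unmoved stays open. Also open, going by these compounds, is whether an ethyl group could replace the methyl group on the neighbouring ring atom, as that methyl group is the same in compound 1 and compound 3.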